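Nitro-hydroxyphenyl variants of a beta-lactam antiproliferative series

This account rests on a few compounds, and the source may have more. Where it says the series, first, only, none or still open, it means among the compounds named here.

Measured so far:
compound 1 `COc1ccc([C@@H]2[C@H](Oc3ccccc3)C(=O)N2c2cc(OC)c(OC)c(OC)c2)cc1OC` — 26000 nM
compound 2 `COc1ccc([C@@H]2[C@H](Oc3ccccc3)C(=O)N2c2cc(OC)c(OC)c(OC)c2)c([N+](=O)[O-])c1O` — 89000 nM

In a functional assay on MCF7 cells (Homo sapiens) for antiproliferative activity, read by MTT assay, with stated times of 24 h and 72 h (on this read-out lower numbers stand for stronger inhibition and higher numbers for weaker inhibition), compound 1 gives 26000 nM, the lowest of the two numbers; compound 2 gives 89000 nM. Within the data shown here, the step of a 3.4-fold higher number from compound 1 to compound 2 (0.53 log units; beyond the scatter) is the only measured step and is modest. Compound 3 `COc1cc([N+](=O)[O-])c([C@@H]2[C@H](Oc3ccccc3)C(=O)N2c2cc(OC)c(OC)c(OC)c2)cc1O` is not yet measured. It differs from compound 1 by a group of 12 heavy atoms (7 carbon, 1 nitrogen, 4 oxygen; one six-membered aromatic ring of carbon only) in place of a group of 10 heavy atoms (8 carbon, 2 oxygen; one six-membered aromatic ring of carbon only), on a saturated ring carbon. The same kind of exchange, on the same carbon, produced the step from compound 1 to compound 2; a step of similar size and direction is therefore expected for compound 3, a 2.7-fold higher number from compound 1 to compound 3 (0.43 log units; beyond the scatter), and compound 3 is estimated at 70000 nM, between 30000 nM and 180000 nM.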

Compound 3, half-maximal inhibitory concentration: 59000 nM
Compound 3: the middle estimate sits 1.2-fold (0.07 log units) above what was measured; the range from low to high includes it.
By their numbers in this assay, from the lowest: compound 1; then compounds 3 and 2 (each within the scatter of the next).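

In this assay, a second arrangement of the nitro and hydroxy groups on the phenyl ring also departs from the 3,4-dimethoxyphenyl group, a 2.3-fold higher number from compound 1 to compound 3 (0.36 log units; beyond the scatter), so the weaker number is not confined to compound 2. The two arrangements are not separated, a 1.5-fold lower number from compound 2 to compound 3 (0.18 log units; within the scatter), and their order cannot be read. Still open, on these data alone, is whether the nitro group or the hydroxy group alone accounts for the step, and what an amino group in place of the nitro group would give. No measurement at hand gives a reason for these steps.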